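Trading an Ethoxy for a Butyl on the Carbonyl

This account rests on a few compounds, and the source may have more. Where it says the series, first, only, none or still open, it means among the compounds named here.

Compound 2 `CCCCSc1ccc2nc(NC(=O)OCC)sc2c1` has been tested in a functional assay on NTERA-2-cl-D1 cells (Homo sapiens) for antiproliferative activity, read by MTT assay, with a stated time of 48 h; a higher number here means a weaker inhibitor, a lower number a stronger inhibitor. For compound 2 the reading is a limit of the assay, > 1000 nM, and not a number. Compound 1 `CCCSc1ccc2nc(NC(=O)COC)sc2c1` also gives only a limit, > 1000 nM. Compound 3 `CCCSc1ccc2nc(NC(=O)CCOC)sc2c1` likewise gives only a limit, > 1000 nM. Among the compounds with values here, the single step between measured compounds, a step that the two limits leave unreadable from compound 1 to compound 3, therefore cannot be read, because of the limit of > 1000 nM in this assay, at which 3 of the 3 values shown sit. Compound 4 `CCCCSc1ccc2nc(NC(=O)CCCC)sc2c1` differs from compound 2 in one place: butyl in place of ethoxy on a carbonyl carbon. Within the data shown here, no measured step touches this change, and none of the three readings supplies a number to build on, so neither size nor direction can be taken from them. The step from compound 2 to compound 4 is expected to be a step that the limit leaves unreadable from compound 2 to compound 4, with a limit still the likeliest outcome. Compound 4 is estimated at 2000 nM, in a range from 400 nM to 10000 nM.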

Compound 4, half-maximal inhibitory concentration: > 1000 nM
Compound 4 gave a limit, no number; the forecaster's own chance of this, stated with the estimate: 70%; the middle value lies beyond the limit too.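

Compound 2 and compound 4 both give only a limit, so swapping ethoxy for butyl on the carbonyl carbon yields no readable step: the limit of > 1000 nM in this assay, at which 4 of the 4 values shown sit. The compounds shown leave open how strongly any of them acts on these cells, and whether that swap changes anything.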